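Propoxy in Place of Isopropylamino: Cytotoxicity Outlook

This account rests on a few compounds, and the source may have more. Where it says the series, first, only, none or still open, it means among the compounds named here.

Compound 1 `COCCOc1nc(N)nc2c1ncn2/C=C1/CC1(CO)CO` in an ADME assay on MOLT-3 cells (Homo sapiens) for cytotoxicity, with a stated time of 7 days (a higher number here means that more compound is tolerated, a lower number that less compound is tolerated), gives > 20000 nM, which is a limit of the assay and not a number.
Compound 2 `CN(C)c1nc(N)nc2c1ncn2/C=C1/CC1(CO)CO` in this assay gives "not determined" (no result reported).
Compound 3 `CC(C)Nc1nc(N)nc2c1ncn2/C=C1/CC1(CO)CO` in this assay gives "not determined" (no result reported).

Compound 3 therefore stands without a number in this assay; of the other two entries, one sits at the limit of > 20000 nM in this assay, at which 1 of the 3 values shown sits, and the other is also without a number. Among the compounds with values here, no step between measured compounds can be read, so no measured size of change is available. Compound 4 `CCCOc1nc(N)nc2c1ncn2/C=C1/CC1(CO)CO` differs from compound 3 by propoxy in place of isopropylamino on an aromatic carbon. In this assay no step beyond the usual scatter is expected for this change. Compound 4 is expected to give about 20000 nM, within the range 8000 nM to 60000 nM, most likely reported as a limit.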

Compound 4, half-maximal cytotoxic concentration: > 20000 nM
Compound 4 ended at the assay's limit; the forecaster's own chance of this, stated with the estimate: 75%; the middle value lies on the limit itself.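

In this assay compound 4 gives > 20000 nM, which is a limit of the assay and not a number. Within the data shown here, compound 1 also stands at a limit, so no step between compound 1 and compound 4 can be read. The compounds shown leave open where any of the four stands as a single number in this assay.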